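The source may report more compounds than this note shows. Statements on the series, on what has been measured and on what is new or still open speak of the compounds shown alone.

Compound 1 `Cc1ccc2[nH]c(=O)c(/C=N/Nc3ccc([N+](=O)[O-])cc3)cc2c1` and compound 2 `O=c1[nH]c2ccccc2cc1/C=N/Nc1ccc([N+](=O)[O-])cc1` share one core, while compound 3 `Cc1ccc2[nH]c(=O)c(/C=N/c3ccc(S(N)(=O)=O)cc3)cc2c1` and compound 4 `NS(=O)(=O)c1ccc(/N=C/c2cc3ccccc3[nH]c2=O)cc1` share another; how the two cores differ is not broken down here. In a functional assay, read by spectrophotometry, with a stated time of 1 h (on this read-out lower numbers stand for stronger inhibition and higher numbers for weaker inhibition), compound 1 gives 350000 nM, and compound 2 gives 245000 nM. The step between them, a 1.4-fold lower number from compound 1 to compound 2 (0.15 log units; within the scatter), comes from the change (hydrogen in place of methyl on an aromatic carbon). In this assay compound 3 is reported as "not active" (no number reported), so no number stands behind it. Compound 4 carries the same change relative to compound 3, (hydrogen in place of methyl on an aromatic carbon), as compound 2 carries relative to compound 1, and the place is described in the same words. Because the earlier step of a 1.4-fold lower number from compound 1 to compound 2 (0.15 log units; within the scatter) stayed within the usual scatter, the same change is expected to leave compound 4 close to where compound 3 stands, which is without measurable inhibition. Compound 4 is therefore expected to show only very weak inhibition in this assay, around 600000 nM, with a likely range from 200000 nM to 2000000 nM, and a real chance that only a limit rather than a number is reported.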

Compound 4, half-maximal inhibitory concentration: 266000 nM
Estimate against measurement, compound 4: 2.3-fold (0.35 log units) above; the measured number falls inside the stated range.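

Among these compounds, no step from compound 3 to compound 4 can be read, as compound 3 is reported as "not active" with no number, while compound 4 gives 266000 nM. The compounds shown leave open whether hydrogen in place of methyl has the same size of effect on both cores. No measurement shown explains this result.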